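Efficacy in the series: fluoro, chloro and methyl analogues

The compounds below may be only part of what the source reports. "The series", "measured", "known", "first", "only" and "open" are said of these compounds alone.

Measured compounds:
- compound 1 `O=C(O)CCc1ccc(C#Cc2ccnc(F)c2)cc1`: 98%
- compound 2 `O=C(O)CCc1ccc(C#Cc2ccnc(Cl)c2)cc1`: 94%

For the measured compounds named here, in an in vitro functional assay on 1321-N1 cells for agonist activity at Free fatty acid receptor 1 (Homo sapiens), read by fluorescence, spectrophotometry and calcium flux (on this read-out higher numbers stand for larger maximal responses and lower numbers for smaller maximal responses), compound 2 gives 94%, the lower of the two numbers so far, though its gap to compound 1 is within the scatter: a number 4 percentage points lower from compound 1 to compound 2 (within the scatter). Compound 3 `Cc1cc(C#Cc2ccc(CCC(=O)O)cc2)ccn1` is not yet measured. Against compound 2 the change is methyl in place of chloro on an aromatic carbon. Going by the values given here, the only measured step that bears on it is the one from compound 1 to compound 2, which exchanged one group for another at the same position and gave a number 4 percentage points lower from compound 1 to compound 2 (within the scatter), a change inside the scatter. Nothing in the series suggests that a small group at this position moves the maximal response, so the expectation for compound 3 in this assay is a step of about a number 1 percentage points lower from compound 2 to compound 3 (within the scatter), no clear direction beyond the scatter. The estimate for compound 3 is therefore 93%, expected within 80% to 104%.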

Compound 3, largest response reached (reported as efficacy), in percent of the reference or control that the assay uses: 102%
Compound 3: the middle estimate sits 9 percentage points below what was measured, within the range that was stated.
By their numbers in this assay, from the lowest: compounds 2, 1 and 3 (each within the scatter of the next).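

On an aromatic carbon next to the ring nitrogen, methyl in place of chloro gives a number 8 percentage points higher from compound 2 to compound 3 (within the scatter) and methyl in place of fluoro gives a number 4 percentage points higher from compound 1 to compound 3 (within the scatter) in this assay so the read-out separates none of the three groups. The earlier pair held only halogens, whereas compound 3 carries one carbon where compound 2 carries one chlorine, and the maximal response stays within the scatter of both halogen compounds. Nothing measured here gives a reason for this tolerance of the exchange.

As far as these compounds go, whether an amine, a methoxy group or a longer chain at this position would also leave the maximal response within the same scatter stays open. The compounds shown also leave open how the compound with plain hydrogen there would compare.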